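The source may report more compounds than this note shows. Statements on the series, on what has been measured and on what is new or still open speak of the compounds shown alone.

Among the compounds with values here, in a functional assay on DU-145 cells (Homo sapiens) for inhibition, read by trypan blue exclusion, with a stated time of 96 h (a higher number here means a weaker inhibitor of growth, a lower number a stronger inhibitor of growth), compound 1 `Cc1ccc(CS/C(=C/c2cc(C)ccc2C)C(=O)c2ccc(Cl)cc2)cc1` gives 10000 nM and compound 2 `Cc1ccc(CS/C(=C/c2ccccc2F)C(=O)c2ccc(Cl)cc2)cc1` stands level with it at 10000 nM on the numbers so far. The move to compound 3 `Cc1ccc(CS/C(=C/c2ccc(Br)cc2)C(=O)c2ccc(Cl)cc2)cc1` is 4-bromophenyl in place of 2-fluorophenyl on a double-bonded chain carbon bound to a double-bonded chain carbon and amounts to 4-bromophenyl in place of 2-fluorophenyl on a double-bonded chain carbon bound to a double-bonded chain carbon. Within the data shown here, the only measured step at this place is no change at the digits printed from compound 1 to compound 2 (within the scatter) and no 4-bromophenyl compound has been measured yet, so the evidence is thin. The expected step is no change at the digits printed from compound 2 to compound 3 (within the scatter) with nothing beyond the scatter anticipated in this assay here. For compound 3 the estimate is 10000 nM with an expected range of 3000 nM to 20000 nM for now.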

Compound 3, concentration for 50% growth inhibition: 10000 nM
For compound 3 middle estimate and measured number coincide at the digits printed, within the range that was stated.
By their numbers in this assay, from the lowest: compounds 1, 2 and 3 (each within the scatter of the next).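

In this assay the exchange for 4-bromophenyl reads no change at the digits printed from compound 2 to compound 3 (within the scatter) and the exchange of 2,5-dimethylphenyl for the same group reads no change at the digits printed from compound 1 to compound 3 (within the scatter) in this series. On a double-bonded chain carbon bound to a double-bonded chain carbon, three differently substituted phenyl groups, now including a bromine-bearing one, show no separation. No measurement at hand bears on why these values coincide.

Going by these compounds, whether an amine or a carboxylic acid at this place would separate from these phenyl compounds stays open. So does the effect of changing the 4-chlorophenyl on the carbonyl.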